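Swapping the Trimethoxyphenyl Ketone Arm for Isovanillyl

The source may hold more compounds than are shown below. What is called first, only, known or untested is meant among the compounds shown, and "the series" means these compounds.

Measured compounds:
compound 1, `COc1cc(C(=O)/C=C\Nc2ccc(-c3nc4cc(OC)c(OC)c(OC)c4s3)cc2C)cc(OC)c1OC`, 22800 nM
compound 2, `COc1cc(OC)c2sc(-c3ccc(N/C=C\C(=O)c4cc(OC)c(OC)c(OC)c4)cc3)nc2c1`, 26800 nM

Both compounds were tested in a functional assay on MIA PaCa-2 cells (Homo sapiens) for antiproliferative activity, read by sulforhodamine B assay, with a stated time of 48 h; a lower number here means a stronger inhibitor, a higher number a weaker inhibitor. Compound 1 gives 22800 nM, and compound 2 gives 26800 nM. Compound 1 has the lowest of the two numbers, but its gap to compound 2 lies within the scatter, so the two cannot be ordered.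

Compound 3, `COc1ccc(C(=O)/C=C\Nc2ccc(-c3nc4cc(OC)c(OC)c(OC)c4s3)cc2C)cc1O`, has not yet been measured in this assay. It differs from compound 1 in one place: 3-hydroxy-4-methoxyphenyl in place of 3,4,5-trimethoxyphenyl on a carbonyl carbon. Going by the values given here, the two measured compounds give no step to judge this change against. Both sit at weak, similar numbers, and nothing in the data points to the change giving a large move in either direction. Compound 3 is therefore expected to give a number near that of compound 1, with a step of a 1.3-fold higher number from compound 1 to compound 3 (0.12 log units; within the scatter) no larger than the scatter. The estimated value of compound 3 in this assay is 30000 nM, with a range from 8000 nM to 100000 nM.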

Compound 3, half-maximal inhibitory concentration: 15400 nM
For compound 3 the middle estimate is 1.9-fold (0.29 log units) above the measured one; the measured number falls inside the stated range.
By their numbers in this assay, from the lowest: compounds 3, 1 and 2 (each within the scatter of the next).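

In this assay the swap of 3,4,5-trimethoxyphenyl for 3-hydroxy-4-methoxyphenyl on a carbonyl carbon gives a 1.5-fold lower number from compound 1 to compound 3 (0.17 log units; within the scatter) and so cannot be told apart from no change. Going by these compounds alone, this is the first step read at this position, and it shows that the arm can lose heavy atoms and gain a hydrogen-bond donor with no shift beyond the scatter, while compound 1 and compound 3 both remain weak. No supporting measurement bears on this result.

Within the data shown here, the single step changes the whole substitution pattern at once, so the part played by the hydroxy group alone stays unresolved. On these data alone, it also remains open whether an amine or a carboxylic acid on this arm, or the same swap on the core of compound 2, would move the number beyond the scatter.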